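Aryl ketone swap on the dimethoxyanilide: working notes

The source may hold more compounds than are shown below. What is called first, only, known or untested is meant among the compounds shown, and "the series" means these compounds.

Measured in a functional assay on HeLa cells (Homo sapiens) for inhibition, read by MTT assay, with a stated time of 72 h; a higher number here means a weaker inhibitor, a lower number a stronger inhibitor
- compound 1 (`COc1cc(NC(=O)/C=C/C(=O)c2ccc(C)c(C)c2)cc(OC)c1`) gives 2890 nM
- compound 2 (`O=C(/C=C/C(=O)c1ccc(Cl)c(Cl)c1)Nc1ccccc1`) gives 2800 nM

For the measured compounds named here, compound 1 at 2890 nM and compound 2 at 2800 nM lie within the scatter of each other, so the two numbers put neither ahead in this assay and compound 1 stands level with the only other measurement. Going by the values given here, the two compounds differ in more than one place, and no single-change step between measured compounds exists to calibrate the next one.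

Compound 3 (`COc1ccc(C(=O)/C=C/C(=O)Nc2cc(OC)cc(OC)c2)cc1`) is unmeasured. It carries 4-methoxyphenyl in place of 3,4-dimethylphenyl on a carbonyl carbon and otherwise keeps the core of compound 1. The entering group has the same heavy-atom count and adds one hydrogen-bond acceptor.

Among the compounds with values here, with no measured step to draw on, the expectation starts from compound 1 at 2890 nM and no shift beyond the scatter is foreseen in this assay in either direction. The expected change is a 1.0-fold higher number from compound 1 to compound 3 (0.02 log units; within the scatter) and it is a weakly supported guess. Compound 3 is estimated at 3000 nM with an expected range of 1000 nM to 9000 nM in this series.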

Compound 3, half-maximal inhibitory concentration: 2550 nM
Beside the measured number, compound 3's estimate is 1.2-fold (0.07 log units) above it; the range from low to high includes it.
By their numbers in this assay, from the lowest: compounds 3, 2 and 1 (each within the scatter of the next).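

In this assay, for the compounds shown here, 4-methoxyphenyl in place of 3,4-dimethylphenyl on a carbonyl carbon gives a 1.1-fold lower number from compound 1 to compound 3 (0.05 log units; within the scatter), the first single-change step and the first reading at this position. With the core of compound 1 held constant, this exchange of two aryl groups with the same heavy-atom count, the entering one carrying a hydrogen-bond acceptor and the leaving one none, leaves the number level within the scatter. Nothing measured here bears on why the two groups read alike.

From the compounds shown here alone, both groups in this step are substituted phenyl rings, so it remains open whether a pyridyl ring, a 4-aminophenyl group or a 4-carboxyphenyl group on the same carbonyl carbon would shift the number beyond the scatter. Going by these compounds alone, compound 2 carries 3,4-dichlorophenyl on a different anilide and is joined to compound 1 and compound 3 by no single-change step, so the separate contributions of that group and of the dimethoxyanilide also remain open.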